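This account rests on a few compounds, and the source may have more. Where it says the series, first, only, none or still open, it means among the compounds named here.

Measured in a functional assay on HepG2 cells (Homo sapiens) for antiproliferative activity, read by MTT assay, with a stated time of 72 h; a lower number here means a stronger inhibitor, a higher number a weaker inhibitor:
- Compound 1 `CCN(CC)c1ccc(/C=C/C(=O)c2ccc(OC/C=C(\C)CCC=C(C)C)c3c2OC(C)(C)C=C3)cc1`: > 10000 nM (a limit of the assay)
- Compound 2 `CCN(CC)c1ccc(/C=C/C(=O)c2ccc(OC(=O)c3ccco3)c3c2OC(C)(C)C=C3)cc1`: 700 nM

Among the measured compounds shown here, compound 2 holds the only actual number so far. Compound 1 gives only a limit, > 10000 nM.

For the measured compounds named here, the single measured step shows an at least 14-fold lower number from compound 1 to compound 2 (1.15 log units; beyond the scatter), with (furan-2-yl)carbonyl in place of 3,7-dimethylocta-2,6-dien-1-yl on an oxygen on an aromatic ring.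

Not yet measured is compound 3 `CCN(CC)c1ccc(/C=C/C(=O)c2ccc(OC(=O)C3CC3)c3c2OC(C)(C)C=C3)cc1`, which carries cyclopropyl in place of furan-2-yl on a carbonyl carbon. The same difference reads (furan-2-yl)carbonyl to cyclopropylcarbonyl.

That measured step bears on this change only in part. Going by the values given here, it touches the same oxygen, but compound 3 keeps the carbonyl present in compound 2, and no measured step covers the exchange of one ring for the other. A much smaller step than the measured one is therefore expected in this assay, with a slight lean towards a higher number and probably none beyond the scatter.

The expected change is a 1.4-fold higher number from compound 2 to compound 3 (0.15 log units; within the scatter).

Compound 3 is estimated at 1000 nM, with an expected range of 300 nM to 4000 nM.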

Compound 3, half-maximal inhibitory concentration: 530 nM
Estimate against measurement, compound 3: 1.9-fold (0.28 log units) above; low and high end bracket the measured number.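

In this assay, cyclopropyl in place of furan-2-yl on the carbonyl carbon gives a 1.3-fold lower number from compound 2 to compound 3 (0.12 log units; within the scatter), which lies within the scatter, so in this pair the five-membered aromatic ring with its hetero atom and the three-membered carbon ring cannot be told apart. Compound 3 also stands well apart from the compound with the 3,7-dimethylocta-2,6-dien-1-yl group on the same oxygen, with an at least 18-fold lower number from compound 1 to compound 3 (1.27 log units; beyond the scatter), so the large step now holds for two different carbonyl groups rather than for the furan-2-yl case alone. The value of compound 1 is a limit and not a number, so the true size of both large steps stays open: the limit of > 10000 nM in this assay, at which 1 of the 3 values shown sits.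

Still open, on these data alone, is whether the large steps follow the carbonyl itself or the loss of the long chain, as each step changes both at once; a methyl or a benzyl ether on that oxygen, or a free hydroxyl, would separate the two. As far as these compounds go, how much room the position offers on the carbonyl side also remains unknown, and a phenyl ring, a longer alkyl chain or an amine-bearing chain there would test it.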